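Removing a Methoxy Group from a Weak Cytotoxic Schiff Base

A few compounds are considered here, and "the series" means these few. Any claim that something is new, unique, unknown or untested is made for them only; others in the source may bear on it.

Compound 1 `COc1ccc(/C=N/c2c(C)n(C)n(-c3ccccc3)c2=O)cc1` gives 186000000 nM in a functional assay on P388 cells (Mus musculus) for cytotoxicity, read by MTT assay, with a stated time of 72 h; a lower number here means a stronger inhibitor, a higher number a weaker inhibitor.
Compound 2 `COc1ccc(/C=N/c2c(C)n(C)n(-c3ccccc3)c2=O)cc1OC` gives 141000000 nM.
Compound 3 `COc1cc(/C=N/c2c(C)n(C)n(-c3ccccc3)c2=O)ccc1O` gives 316000000 nM.

Among these three, compound 3 shows the highest number, and its difference from compound 1 lies within the scatter, while a 2.2-fold higher number from compound 2 to compound 3 (0.35 log units; beyond the scatter) is a modest step beyond it. Compound 4 `Cc1c(/N=C/c2ccc(O)cc2)c(=O)n(-c2ccccc2)n1C` differs from compound 3 by hydrogen in place of methoxy on an aromatic carbon, the hydrogen entering ortho to a hydroxy group. Within the data shown here, the only measured step that adds or removes a methoxy group is a 1.3-fold lower number from compound 1 to compound 2 (0.12 log units; within the scatter), which stayed within the scatter. A comparable small effect, in either direction, is therefore expected here: a 1.2-fold lower number from compound 3 to compound 4 (0.08 log units; within the scatter), no step beyond the scatter. Compound 4 is expected to give about 260000000 nM, within a range from 120000000 nM to 600000000 nM.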

Compound 4, half-maximal inhibitory concentration: 537000000 nM
Estimate against measurement, compound 4: 2.1-fold (0.32 log units) below; measured number inside the range.
By their numbers in this assay, from the lowest: compounds 2, 1, 3 and 4 (each within the scatter of the next, the first and the last beyond it).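

Removing the methoxy group ortho to a hydroxy group gives a 1.7-fold higher number from compound 3 to compound 4 (0.23 log units; within the scatter), so taking this group away, like adding one on the core of compound 1, does not carry the number beyond the usual scatter, and the two steps agree: the same change on two cores in this assay, a 1.3-fold lower number (0.12 log units; within the scatter) from compound 1 to compound 2 and a 1.7-fold lower number (0.23 log units; within the scatter) from compound 4 to compound 3, 1.3-fold (0.11 log units) apart, within the scatter of two such steps. Hydrogen in place of methyl on the oxygen gives a 2.9-fold higher number from compound 1 to compound 4 (0.46 log units; beyond the scatter), a modest weakening that matches the earlier step between compound 2 and compound 3: the same change on two cores in this assay, a 2.2-fold higher number (0.35 log units; beyond the scatter) from compound 2 to compound 3 and a 2.9-fold higher number (0.46 log units; beyond the scatter) from compound 1 to compound 4, 1.3-fold (0.11 log units) apart, within the scatter of two such steps.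

The compounds shown carry only hydrogen, hydroxy or methoxy on this ring. As far as these compounds go, what an amine, a carboxylic acid or a longer chain would do here remains open.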